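The source may hold more compounds than are shown below. What is called first, only, known or untested is meant among the compounds shown, and "the series" means these compounds.

Measured in an assay on HEK293 cells for antagonist activity at transient receptor potential M8 protein (Canis lupus familiaris), read by fluorescence and calcium flux, with a stated time of 5 min (on this read-out higher numbers stand for weaker inhibition and lower numbers for stronger inhibition), so far:
compound 1 `O=C(C(Nc1ccccc1F)c1ccc(C(F)(F)F)cc1)N1CCCC1c1ccccc1F`, 7 nM;
compound 2 `O=C(C(Nc1ccccc1F)c1ccc(Br)cc1)N1CCC[C@H]1c1ccccc1F`, 9 nM;
compound 3 `O=C(C(Nc1ccccc1F)c1cc2ccccc2s1)N1CCC[C@H]1c1ccccc1F`, 3 nM.

Compound 3 carries the lowest number of the three, and its distance to both compound 1 and compound 2 lies beyond the scatter. Compound 4 `O=C(C(Nc1ccccc1F)c1ccc2c(c1)CCO2)N1CCC[C@H]1c1ccccc1F` differs from compound 3 by a group of 9 heavy atoms (8 carbon, 1 oxygen; one five-membered non-aromatic ring with 1 hetero atom, one six-membered aromatic ring of carbon only) in place of a group of 9 heavy atoms (8 carbon, 1 sulfur; one five-membered aromatic ring with 1 hetero atom, one six-membered aromatic ring of carbon only), on a saturated chain carbon bound to a carbonyl carbon and a nitrogen on an aromatic ring. For the measured compounds named here, the only measured step at this position is a 3.0-fold lower number from compound 2 to compound 3 (0.48 log units; beyond the scatter), where a bicyclic group with an aromatic five-membered ring replaced 4-bromophenyl. Going by the values given here, no step between two bicyclic groups at this position has been measured, so the present change is not directly covered. With the five-membered ring now non-aromatic, a modest step upward from compound 3 to compound 4 is expected, a 2.0-fold higher number from compound 3 to compound 4 (0.30 log units; within the scatter), near the scatter edge. Compound 4 is estimated at 6 nM, range 2 nM to 20 nM.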

Compound 4, half-maximal inhibitory concentration: 14 nM
Beside the measured number, compound 4's estimate is 2.3-fold (0.37 log units) below it; the measured number falls inside the stated range.
By their numbers in this assay, from the lowest: compound 3; then compounds 1, 2 and 4 (each within the scatter of the next).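

On a saturated chain carbon bound to a carbonyl carbon and a nitrogen on an aromatic ring, two bicyclic groups of equal heavy-atom count are not interchangeable: the change gives a 4.7-fold higher number from compound 3 to compound 4 (0.67 log units; beyond the scatter). The advantage of 1-benzothiophen-2-yl over 4-bromophenyl does not carry over to this oxygen-containing bicyclic group, with a 1.6-fold higher number from compound 2 to compound 4 (0.19 log units; within the scatter). No measurement given here bears on the reason for this difference.

The two bicyclic groups differ in hetero atom and in aromaticity of the five-membered ring, so these remain unseparated. A 1-benzofuran-2-yl group would address that question.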